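Cyclohexyl imidazopyridine-fused cores: swapping the pendant aromatic ring

The compounds below may be only part of what the source reports. "The series", "measured", "known", "first", "only" and "open" are said of these compounds alone.

The measured compounds:
compound 1, `Clc1ccc(-c2cn3ccnc3c(-c3ccc4ncn(C5CCCCC5)c4c3)n2)cc1`, 4.14% in a functional assay on NCI-H460 cells (Homo sapiens) for inhibition, read by sulforhodamine B assay, with a stated time of 48 h, tested at 10 uM; on this read-out higher numbers stand for more inhibition at the one concentration tested (going by the name of the read-out) and lower numbers for less inhibition;
compound 2, `COc1ccccc1-c1cn2ccnc2c(-c2ccc3ncn(C4CCCCC4)c3c2)n1`, 9.62% in this assay;
compound 3, `c1csc(-c2cn3ccnc3c(-c3ccc4ncn(C5CCCCC5)c4c3)n2)c1`, 1.3% in this assay.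

All three share one core and differ only in the aromatic group on it. The steps of a number 2.8 percentage points lower from compound 1 to compound 3 (within the scatter) and a number 8.3 percentage points lower from compound 2 to compound 3 (within the scatter) are both within the scatter, so compound 3 stands together with compound 1 and compound 2 at low inhibition, with nothing separating the three beyond repeat noise.

Compound 4, `FC(F)(F)c1cccc(-c2cn3ccnc3c(-c3ccc4ncn(C5CCCCC5)c4c3)n2)c1`, has not been measured. It differs from compound 3 by 3-(trifluoromethyl)phenyl in place of thiophen-2-yl on an aromatic carbon. The two steps that bear on this are the ones leading into compound 3 from a six-membered ring, a number 2.8 percentage points lower from compound 1 to compound 3 (within the scatter) and a number 8.3 percentage points lower from compound 2 to compound 3 (within the scatter), and both were within the scatter. Returning to a six-membered ring, now carrying a trifluoromethyl group, is therefore expected to give no step beyond the scatter in this assay.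

Compound 4 is estimated at 5%, between -7% and 18%. This corresponds to an expected step of a number 3.7 percentage points higher from compound 3 to compound 4 (within the scatter).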

Compound 4, a percentage reported as inhibition, at one concentration (the size of the read-out at that concentration, not a potency): 4.38%
For compound 4 the middle estimate is 0.6 percentage points above the measured one, and the stated range covers the measured number.
By their numbers in this assay, from the lowest: compounds 3, 1, 4 and 2 (each within the scatter of the next).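

In this assay, 3-(trifluoromethyl)phenyl in this place gives no separation from thiophen-2-yl (a number 3.1 percentage points higher from compound 3 to compound 4 (within the scatter)), from 2-methoxyphenyl (a number 5.2 percentage points lower from compound 2 to compound 4 (within the scatter)) or from 4-chlorophenyl (a number 0.2 percentage points higher from compound 1 to compound 4 (within the scatter)). The earlier compounds had shown this only for three aromatic groups, and a fluorinated group with more heavy atoms than thiophen-2-yl now joins them, so that among the phenyl groups shown neither the substituent nor its place on the ring separates the compounds. Nothing available explains this low level of inhibition.

The compounds shown leave open whether any group in this place can raise the number beyond the scatter, for instance a ring carrying an amine or a carboxylic acid. They also leave open whether an ethyl chain or a piperidine in place of the cyclohexyl would change the picture.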